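The source may report more compounds than this note shows. Statements on the series, on what has been measured and on what is new or still open speak of the compounds shown alone.

In a functional assay on NCI-H226 cells (Homo sapiens) for inhibition, read by sulforhodamine B assay, with a stated time of 48 h (on this read-out higher numbers stand for weaker inhibition of growth and lower numbers for stronger inhibition of growth), two compounds sharing one core have been measured so far. Compound 1 `Cc1ccc(NC(=O)/C=C/c2ccccc2)c(C(N)=O)c1` gives 7280 nM, and compound 2 `NC(=O)c1cc(Br)ccc1NC(=O)/C=C/c1ccccc1` gives 2610 nM, the lower of the two numbers. Compound 3 `NC(=O)c1cc(I)ccc1NC(=O)/C=C/c1ccccc1` has not yet been measured. Its structure departs from that of compound 2 in one place: iodo in place of bromo on an aromatic carbon, meta to a carbamoyl group and para to a large group. Among the compounds with values here, only one measured step bears on this change, and it falls at the same place: a 2.8-fold lower number from compound 1 to compound 2 (0.45 log units; beyond the scatter), a modest step with bromo in place of methyl. Within the data shown here, no measured step yet shows what happens when bromo itself leaves, so this evidence is indirect. In this assay, the expectation is therefore for no change beyond the scatter, with a slight lean towards a lower number. The estimated step is a 1.2-fold lower number from compound 2 to compound 3 (0.07 log units; within the scatter). The estimated value for compound 3 is 2200 nM, with an expected range from 900 nM to 5300 nM.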

Compound 3, concentration for 50% growth inhibition: 1090 nM
The estimate for compound 3 lay 2.0-fold (0.30 log units) above the measured number, within the range that was stated.
By their numbers in this assay, from the lowest: compound 3; then compound 2; then compound 1.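

In this assay the position on an aromatic carbon, meta to a carbamoyl group and para to a large group, now has a step in which bromo itself leaves: iodo in its place gives a 2.4-fold lower number from compound 2 to compound 3 (0.38 log units; beyond the scatter) and so the fall in the number does not stop at bromo. Measured against the methyl compound, iodo gives a 6.7-fold lower number from compound 1 to compound 3 (0.82 log units; beyond the scatter) and this places the three groups in the order methyl, bromo, iodo from the highest number to the lowest, with none of the three compounds going against that order, though three compounds at one position make only a short series. No measurement at hand accounts for this order.

The compounds shown leave open where hydrogen, fluoro or chloro would fall in this order, and whether the number keeps falling with a group of a different kind at this position, such as a nitrile, a methoxy group or a trifluoromethyl group. They also leave open whether iodo gives a step of similar size when the carbamoyl group is replaced by a carboxylic acid or when the rest of the shared core is changed.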